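The source may report more compounds than this note shows. Statements on the series, on what has been measured and on what is new or still open speak of the compounds shown alone.

Of the compounds shown here, two have been measured so far. Compound 1 `CCOC(=O)c1cccc(-c2ccc(OCC)nc2)c1` and compound 2 `CCOc1ccc(-c2cccc(C)c2)cc1` were both tested in an assay on COS-7 cells for inhibition of patatin-like phospholipase domain-containing protein 2 (Mus musculus); a higher number here means a weaker inhibitor, a lower number a stronger inhibitor. In this assay compound 1 gives 130000 nM. In this assay compound 2 gives 70000 nM, and the two values lie within the usual scatter of each other, so neither compound can be called the stronger; both sit at weak inhibition. The next compound, compound 3 `CCOc1ccc(-c2cccc(NC(C)=O)c2)cc1`, has not yet been measured in this assay. It differs from compound 2 in one place: acetamido in place of methyl on an aromatic carbon. For the measured compounds named here, no step between two measured compounds shows what such an exchange does here, and compound 1 and compound 2 differ in more than one place, so their pair shows only that both numbers are high. Compound 3 is therefore expected to remain in the same weak region, and the expected step of a 1.1-fold higher number from compound 2 to compound 3 (0.06 log units; within the scatter) is no larger than the scatter, in either direction. Compound 3 is estimated at 80000 nM, with a range from 25000 nM to 250000 nM.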

Compound 3, half-maximal inhibitory concentration: 200000 nM
Compound 3: middle estimate off by 2.5-fold (0.40 log units), on the low side; measured number inside the range.
By their numbers in this assay, from the lowest: compounds 2, 1 and 3 (each within the scatter of the next, the first and the last beyond it).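

For the compounds shown here, exchanging the methyl of compound 2 for acetamido, on an aromatic carbon meta to a group of 9 heavy atoms, gives the first step in this assay that can be read at a single place: a 2.9-fold higher number from compound 2 to compound 3 (0.46 log units; beyond the scatter) and thus a modest loss of inhibition that lies beyond the scatter. This position therefore responds to what is placed on it, and acetamido, which brings a hydrogen-bond donor and a hydrogen-bond acceptor that methyl lacks, does not improve inhibition on this core. No measurement accompanies this step that would account for its direction.

With only one step at this position, the compounds shown leave open whether the higher number goes with the amide hydrogen, the carbonyl or the larger group as a whole, and whether an amine, a carboxylic acid or a longer chain in the same place would give a lower number than methyl. They also leave open whether the same exchange on the core of compound 1 would give a step of similar size.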